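This account rests on a few compounds, and the source may have more. Where it says the series, first, only, none or still open, it means among the compounds named here.

Compound 3, `COc1ccc(-c2cn(-c3cccc(C(=O)/C=C/c4cc(OC)c(OC)c(OC)c4)c3)c(=O)[nH]2)cc1`, and compound 1, `COc1cc(/C=C/C(=O)c2cccc(-n3cc(-c4ccc(Cl)cc4)[nH]c3=O)c2)cc(OC)c1OC`, share a core and differ only where (chloro in place of methoxy on an aromatic carbon). In a functional assay on SF-539 cells (Homo sapiens) for inhibition (a higher number here means a weaker inhibitor of growth, a lower number a stronger inhibitor of growth), compound 3 gives 2000 nM, and compound 1 gives 3490 nM, so the change made a 1.7-fold higher number from compound 3 to compound 1 (0.24 log units; within the scatter).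

Compound 2, `COc1ccc(-c2cn(-c3cccc(C(=O)/C=C/c4ccc(O)c(OC)c4)c3)c(=O)[nH]2)cc1`, carries a different core from compound 3: the two cores differ by 4-hydroxy-3-methoxyphenyl in place of 3,4,5-trimethoxyphenyl on a double-bonded chain carbon bound to a double-bonded chain carbon. In this assay compound 2 gives 2250 nM, and the change from compound 2 to compound 3 brought a 1.1-fold lower number from compound 2 to compound 3 (0.05 log units; within the scatter).

Compound 4, `COc1cc(/C=C/C(=O)c2cccc(-n3cc(-c4ccc(Cl)cc4)[nH]c3=O)c2)ccc1O`, stands to compound 2 as compound 1 stands to compound 3: it differs from compound 2 by chloro in place of methoxy on an aromatic carbon, the same change at the same place as the one already measured. For compound 4 the step is therefore expected to be a 1.5-fold higher number from compound 2 to compound 4 (0.17 log units; within the scatter), resting on the earlier step from compound 3 to compound 1, which was a 1.7-fold higher number from compound 3 to compound 1 (0.24 log units; within the scatter), and on the value of compound 2, 2250 nM. On that basis compound 4 is estimated at 3300 nM in this assay, expected to fall between 1600 nM and 7000 nM.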

Compound 4, concentration for 50% growth inhibition: 1780 nM
Estimate against measurement, compound 4: 1.9-fold (0.27 log units) above; low and high end bracket the measured number.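

Placing chloro where methoxy stood, on the core that carries the 4-hydroxy-3-methoxyphenyl group, gives a 1.3-fold lower number from compound 2 to compound 4 (0.10 log units; within the scatter) in this assay. The two steps point in opposite directions on paper, but neither that nor the gap between them can be told apart from ordinary repeat-to-repeat variation: the same change on two cores in this assay, a 1.7-fold higher number (0.24 log units; within the scatter) from compound 3 to compound 1 and a 1.3-fold lower number (0.10 log units; within the scatter) from compound 2 to compound 4, 2.2-fold (0.34 log units) apart, within the scatter of two such steps. So on these two cores, the change from 4-methoxyphenyl to 4-chlorophenyl leaves the number within the scatter, and nothing here shows that the core alters its effect; it also does not prove that the change carries over unaltered to other cores, since steps this small on only two cores give no firm size to carry.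

As far as these compounds go, it remains open whether another group in this place, such as an amine or a carboxylic acid, would move the number beyond the scatter. From the compounds shown here alone, it also remains open whether a step of that larger size would hold from one core to the other.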